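This account rests on a few compounds, and the source may have more. Where it says the series, first, only, none or still open, it means among the compounds named here.

Measured so far in a functional assay on HL-60 cells (Homo sapiens) for antiproliferative activity, read by MTT assay, with a stated time of 48 h; on this read-out lower numbers stand for stronger inhibition and higher numbers for weaker inhibition:
- compound 1 `O=C(CCCCCC(=O)Nc1ccc(O)c(C(=O)Nc2ccc(F)c(Cl)c2)c1)NO`: > 100000 nM, a limit and not a number
- compound 2 `C#Cc1cccc(NC(=O)c2cc(NC(=O)CCCCCC(=O)NO)ccc2O)c1`: > 100000 nM, a limit and not a number
- compound 3 `COc1cc(O)c(C(=O)Nc2ccc(F)c(Cl)c2)cc1NC(=O)CCCCCC(=O)NO`: 9830 nM

In this assay, among the compounds with values here, compound 3 gives 9830 nM, the only true number in the set. Compound 1 and compound 2 share (the limit of > 100000 nM in this assay, at which 2 of the 3 values shown sit).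

Compound 4 `C#Cc1cccc(NC(=O)c2cc(NC(=O)CCCCCC(=O)NO)c(OC)cc2O)c1` keeps the methoxy of compound 3 and changes one group: 3-ethynylphenyl in place of 3-chloro-4-fluorophenyl on an amide-type nitrogen.

Within the data shown here, two measured steps bear on this. The methoxy, which compound 4 retains, accounts for an at least 10-fold lower number from compound 1 to compound 3 (1.00 log units; beyond the scatter). The same exchange of groups, made without the methoxy, is a step that the two limits leave unreadable from compound 1 to compound 2, so the data give no size for it and no direction.

With nothing to suggest a shift either way, no change beyond the scatter is expected in this assay, although compound 4 could still reach the limit. The expected step is a 1.2-fold higher number from compound 3 to compound 4 (0.09 log units; within the scatter).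

For compound 4, the estimated value is 12000 nM, with an expected range of 4000 nM to 40000 nM.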

Compound 4, half-maximal inhibitory concentration: 28600 nM
Compound 4: middle estimate off by 2.4-fold (0.38 log units), on the low side; measured number inside the range.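

With the methoxy present, the exchange of 3-chloro-4-fluorophenyl for 3-ethynylphenyl on the amide-type nitrogen becomes readable in this assay: it gives a 2.9-fold higher number from compound 3 to compound 4 (0.46 log units; beyond the scatter), so on this core the group on that nitrogen does matter, and 3-chloro-4-fluorophenyl gives the lower number. The methoxy also lowers the number with the 3-ethynylphenyl group in place, giving an at least 3.4-fold lower number from compound 2 to compound 4 (0.54 log units; beyond the scatter). Its gain is therefore not tied to a single group on the amide nitrogen, as the two cores show: the same change on two cores in this assay, an at least 10-fold lower number (1.00 log units; beyond the scatter) from compound 1 to compound 3 and an at least 3.4-fold lower number (0.54 log units; beyond the scatter) from compound 2 to compound 4; the limit leaves it open whether they differ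

The compounds shown leave open whether another group on the same aromatic carbon, such as ethoxy or a fluorine atom, would lower the number as the methoxy does. They also leave open whether the chlorine or the fluorine matters more within 3-chloro-4-fluorophenyl, which a 3-chlorophenyl or a 4-fluorophenyl group on that nitrogen could separate.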